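From compound 2 to compound 3: one aryl exchange

This account rests on a few compounds, and the source may have more. Where it says the series, first, only, none or still open, it means among the compounds named here.

In a functional assay on HepG2 cells (Homo sapiens) for cytotoxicity, read by MTT assay, with a stated time of 72 h (a lower number here means a stronger inhibitor, a higher number a weaker inhibitor), compound 1 `COc1cc2ncnc(Nc3ccc(F)c(Cl)c3)c2cc1NC(=O)N/N=C/c1cccc(Cl)c1Cl` gives 26100 nM and compound 2 `COc1cc2ncnc(Nc3ccc(F)c(Cl)c3)c2cc1NC(=O)N/N=C/c1cc(OC)c(OC)c(OC)c1` gives 30100 nM, so compound 2 stands level with compound 1. Compound 3 `COc1cc2ncnc(Nc3ccc(F)c(Cl)c3)c2cc1NC(=O)N/N=C/c1cc(Br)c(O)c(Br)c1` has 3,5-dibromo-4-hydroxyphenyl in place of 3,4,5-trimethoxyphenyl on a carbon with a double bond to nitrogen. Among the compounds with values here, the only measured step bearing on this exchange, a 1.2-fold higher number from compound 1 to compound 2 (0.06 log units; within the scatter), concerns the same place and lies within the scatter, so no step beyond the scatter is expected in this assay. The expected step is a 1.2-fold lower number from compound 2 to compound 3 (0.08 log units; within the scatter). For compound 3 the estimated value is 25000 nM, within a range of 10000 nM to 55000 nM.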

Compound 3, half-maximal inhibitory concentration: 36800 nM
Beside the measured number, compound 3's estimate is 1.5-fold (0.17 log units) below it; low and high end bracket the measured number.
By their numbers in this assay, from the lowest: compounds 1, 2 and 3 (each within the scatter of the next).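

In this assay the exchange gives a 1.2-fold higher number from compound 2 to compound 3 (0.09 log units; within the scatter) and, against the dichlorinated group, a 1.4-fold higher number from compound 1 to compound 3 (0.15 log units; within the scatter) so 3,5-dibromo-4-hydroxyphenyl, which brings a hydrogen-bond donor that 3,4,5-trimethoxyphenyl does not have, stands level with both earlier groups. All three aryl groups on this carbon with a double bond to nitrogen now lie within the scatter of one another. Nothing at hand offers an explanation for this. As far as these compounds go, whether an amine or a carboxylic acid on the ring, or a longer chain in place of the ring, would move the number stays open.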